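Aryl variation on the chain carbon: outlook for compound 4

The compounds below may be only part of what the source reports. "The series", "measured", "known", "first", "only" and "open" are said of these compounds alone.

Compound 1, `COC(=O)[C@H](CCSC)NC(=O)c1ccc(NCc2cncn2Cc2ccccc2C)cc1-c1ccccc1`: in a functional assay on NIH3T3 cells (Mus musculus) (a lower number here means that less compound is needed, a higher number that more compound is needed for the effect), compound 1 gives > 10 uM, a limit.
Compound 2, `COC(=O)[C@H](CCSC)NC(=O)c1ccc(NCc2cncn2Cc2ccc([N+](=O)[O-])cc2)cc1-c1ccccc1`: in this assay compound 2 gives > 10 uM, a limit.
Compound 3, `COC(=O)[C@H](CCSC)NC(=O)c1ccc(NCc2cncn2Cc2cccc(Cl)c2)cc1-c1ccccc1`: in this assay compound 3 gives > 10 uM, a limit.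

Compound 3 thus stands only at a limit in this assay, and the other two values are limits as well, (the limit of > 10 uM in this assay, at which 3 of the 3 values shown sit). Compound 4, `COC(=O)[C@H](CCSC)NC(=O)c1ccc(NCc2cncn2Cc2ccc(-c3ccccc3)cc2)cc1-c1ccccc1`, carries 4-phenylphenyl in place of 3-chlorophenyl on a saturated chain carbon bound to an aromatic nitrogen. Among the measured compounds shown here, the steps that bear on this change all run between limits: a step that the two limits leave unreadable from compound 1 to compound 2, a step that the two limits leave unreadable from compound 1 to compound 3 and a step that the two limits leave unreadable from compound 2 to compound 3, none readable in size or direction. No aryl variation on this carbon has yet given a value inside the readable range. The expected step is therefore a step that the limit leaves unreadable from compound 3 to compound 4, with no direction beyond the scatter, and most likely another limit. Compound 4 is estimated at 15 uM in this assay, within 4 uM to 60 uM.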

Compound 4, concentration for half-maximal effect: > 10 uM
Compound 4 ended at the assay's limit; the forecaster's own chance of this, stated with the estimate: 80%; the middle value is on the limit's open side.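

In this assay compound 4 gives > 10 uM, a limit. Its steps from compound 1, compound 2 and compound 3 cannot be read. The compounds shown leave open whether any aryl group on this chain carbon gives a readable value: the limit of > 10 uM in this assay, at which 4 of the 4 values shown sit.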